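Ester to Acid: Estimating Binding of Compound 4

The source may report more compounds than this note shows. Statements on the series, on what has been measured and on what is new or still open speak of the compounds shown alone.

Of the compounds shown here, three have been measured in an assay on striatum for binding affinity to 5-hydroxytryptamine receptor 1D (Cavia porcellus), in the presence of a further agent that is not named here; a lower number here means a stronger inhibitor, a higher number a weaker inhibitor. Compound 1 `COc1ccc(NC(=O)c2ccc(-c3ccncc3)cc2)cc1N1CCN(C)CC1` gives 5.01 nM. Compound 2 `COc1ccc(NC(=O)c2ccc(-c3ccc(C(=O)N(C)C)cc3C)cc2)cc1N1CCN(C)CC1` gives 5.01 nM. Compound 3 `COCCOC(=O)c1ccc(-c2ccc(NC(=O)c3ccc(OC)c(CCCN(C)C)c3)cc2)c(C)c1` gives 3.16 nM. Compound 3 stands at the low end of the three numbers, but its gaps to compound 1 and to compound 2 both lie within the scatter, so nothing separates the three.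

Among the compounds with values here, the only step between measured compounds that differ in a single place is no change at the digits printed from compound 1 to compound 2 (within the scatter), and it lies within the scatter: swapping one aromatic group for another left the number where it was.

Compound 4 `COc1ccc(C(=O)Nc2ccc(-c3ccc(C(=O)O)cc3C)cc2)cc1CCCN(C)C` has not yet been measured. It differs from compound 3 in one place: hydrogen in place of 2-methoxyethyl on an oxygen next to a carbonyl group. Within the data shown here, no measured step touches this oxygen next to the carbonyl group; the single measured step concerns another part of the molecule and gives no guide to the size or direction of this change. The expectation for compound 4 therefore rests on compound 3 alone, and the expected step of a 3.2-fold higher number from compound 3 to compound 4 (0.50 log units; beyond the scatter) is modest and uncertain. Compound 4 is expected to give 10 nM, with a range from 3 nM to 40 nM.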

Compound 4, inhibition constant: 31.6 nM
The estimate for compound 4 lay 3.2-fold (0.50 log units) below the measured number; the measured number falls inside the stated range.
By their numbers in this assay, from the lowest: compounds 3, 1 and 2 (each within the scatter of the next); then compound 4.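

Replacing 2-methoxyethyl with hydrogen on the oxygen next to a carbonyl group, which turns (2-methoxyethoxy)carbonyl into carboxy, gives a 10-fold higher number from compound 3 to compound 4 (1.00 log units; beyond the scatter) in this assay. Within the data shown here, this shows that a change at this place can move the number beyond the scatter, whereas the only earlier step, no change at the digits printed from compound 1 to compound 2 (within the scatter), concerned another part of the molecule and stayed within the scatter. Nothing measured here explains why this change raises the number.

The compounds shown place only 2-methoxyethyl and hydrogen on this oxygen, so they leave open how the number would respond to a methyl or ethyl group there, or to a carboxamide in place of the carboxy group. They also leave open whether a carboxy group in place of the dimethylcarbamoyl group of compound 2 would raise the number in the same way on that different core.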